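The source may report more compounds than this note shows. Statements on the series, on what has been measured and on what is new or still open speak of the compounds shown alone.

For the measured compounds named here, compound 1 `COc1ccc2c(=O)c(/C=C/C(=O)Nc3ccc(Cl)cc3)coc2c1` gives the higher of the two numbers so far: in a functional assay on Huh-7 cells (Homo sapiens) for inhibition, read by MTT assay, with a stated time of 48 h (on this read-out higher numbers stand for weaker inhibition and lower numbers for stronger inhibition), compound 1 gives 37100 nM, whereas compound 2 `Cc1ccccc1NC(=O)/C=C/c1coc2cc(O)ccc2c1=O` gives 11100 nM in this assay, a gap beyond the scatter; the two differ in more than one place, so no single step is read from them. Compound 3 `COc1ccc2c(=O)c(/C=C/C(=O)Nc3cccc(C)c3)coc2c1` differs from compound 1 only by 3-methylphenyl in place of 4-chlorophenyl on an amide-type nitrogen. With no measured step of this kind in the series, the expected change from this swap is small, a step of a 1.5-fold lower number from compound 1 to compound 3 (0.17 log units; within the scatter) toward a somewhat lower number, likely not beyond the scatter. Compound 3 is therefore estimated at 25000 nM in this assay, within a range of 8000 nM to 70000 nM.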

Compound 3, half-maximal inhibitory concentration: 15500 nM
Compound 3: middle estimate off by 1.6-fold (0.21 log units), on the high side, and the stated range covers the measured number.
By their numbers in this assay, from the lowest: compounds 2 and 3 (each within the scatter of the next); then compound 1.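

The aryl group on the amide-type nitrogen is a position that moves the read-out: 3-methylphenyl in place of 4-chlorophenyl gives a 2.4-fold lower number from compound 1 to compound 3 (0.38 log units; beyond the scatter) on an unchanged core, a modest step. For the compounds shown here, this is the first change read at a single place. No measured evidence bears on the cause of this step.

On these data alone, the swap changes both the substituent and its ring position, so 3-chlorophenyl and 4-methylphenyl remain open as the separating cases. As far as these compounds go, an amine or carboxylic acid on this phenyl ring also remains open, as does whether the step carries over to the core of compound 2.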